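This account rests on a few compounds, and the source may have more. Where it says the series, first, only, none or still open, it means among the compounds named here.

Measured so far:
Compound 1, `CCCCCC/C=C\Cc1c(C)[nH]c2ccccc2c1=O`, in a physicochemical assay for lipophilicity, at pH 7.4 (a higher number here means a more lipophilic compound, a lower number a more polar compound), gives 5.94.
Compound 2, `COc1ccc2[nH]c(C)c(Br)c(=O)c2c1`, in this assay gives 1.62.
Compound 3, `CCCCCCCc1c(C)[nH]c2cc(OC)c(Cl)cc2c1=O`, in this assay gives < 3.83, which is a limit of the assay and not a number.

Compound 3 therefore has no firm place among the three values: what is known is only that it sits at the limit where one of the three values shown falls (the limit of < 3.83 in this assay, at which 1 of the 3 values shown sits). For the measured compounds named here, no pair of the measured compounds differs in a single place, so no measured step is available to lean on.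

Compound 4, `COc1cc2[nH]c(C)c(C)c(=O)c2cc1Cl`, differs from compound 3 in one place: hydrogen in place of hexyl on a saturated chain carbon bound to an aromatic carbon. Six carbon atoms of a chain leave and nothing heavier than a hydrogen arrives.

Since compound 3 offers only a limit, the expected step from compound 3 to compound 4 in this assay is estimated at a step that the limit leaves unreadable from compound 3 to compound 4, a drop well beyond the scatter. Compound 2, which also lacks any long chain, gives 1.62 and marks the polar end of what is shown. For compound 4 the expected value is 2.3, with a range from 1.6 to 3.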

Compound 4, distribution coefficient: 1.86
Beside the measured number, compound 4's estimate is 0.44 log units above it; the measured number falls inside the stated range.
By their numbers in this assay, from the lowest: compounds 2 and 4 (each within the scatter of the next); then compound 1.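

No step from compound 3 to compound 4 can be read in this assay, because compound 3 gives only a limit of the assay and not a number: the limit of < 3.83 in this assay, at which 1 of the 4 values shown sits.

The compounds shown leave open how large a change in this assay goes with hydrogen in place of hexyl on a saturated chain carbon bound to an aromatic carbon.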